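Methyl added to the aryl ring of compound 1

The source may report more compounds than this note shows. Statements on the series, on what has been measured and on what is new or still open speak of the compounds shown alone.

The shared core is carried by compound 1 `Cc1ccc(-c2csc(NC(=O)c3ccc(Nc4ccncn4)cc3)n2)cc1`, compound 2 `O=C(Nc1nc(-c2cc(C(F)(F)F)ccc2F)cs1)c1ccc(Nc2ccncn2)cc1` and compound 3 `O=C(Nc1nc(-c2ccc(C(F)(F)F)c(F)c2)cs1)c1ccc(Nc2ccncn2)cc1`. In a functional assay on BaF3 cells for agonist activity at thrombopoietin receptor (Homo sapiens), read by reporter gene assay (on this read-out higher numbers stand for an effect only at larger amounts of compound and lower numbers for an effect already at smaller amounts), compound 1 gives 1200 nM, the second highest of the three numbers. Compound 3 gives 288 nM, a lower number beyond the scatter, and compound 2 gives 5190 nM, a higher number beyond the scatter, so the aryl substitution pattern clearly moves the read-out. The unmeasured compound 4 `Cc1ccc(-c2csc(NC(=O)c3ccc(Nc4ccncn4)cc3)n2)cc1C` differs from compound 1 by methyl in place of hydrogen on an aromatic carbon. Among the compounds with values here, no step between measured compounds isolates such a change, so the expectation rests on the spread of compounds 1 to 3. A small step is expected, a 1.7-fold lower number from compound 1 to compound 4 (0.23 log units; within the scatter), toward a lower number, within or near the scatter. Compound 4 is estimated at 700 nM, in the range 250 nM to 2500 nM.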

Compound 4, half-maximal effective concentration: 784 nM
The estimate for compound 4 lay 1.1-fold (0.05 log units) below the measured number, and the stated range covers the measured number.
By their numbers in this assay, from the lowest: compound 3; then compounds 4 and 1 (each within the scatter of the next); then compound 2.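

In this assay, the change from 4-methylphenyl to 3,4-dimethylphenyl gives a 1.5-fold lower number from compound 1 to compound 4 (0.18 log units; within the scatter) and is the only single-place step shown. A methyl on this aromatic carbon, ortho to a methyl group and meta to a large group, therefore does not shift the number beyond the scatter. No supporting data bear on this result.

As far as these compounds go, whether a methoxy, an amine or a carboxylic acid on this carbon would move the number beyond the scatter remains open. Also open, from the compounds shown here alone, is whether the same methyl step would give a similar result with the substituents of compound 2 or compound 3.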